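Trimming one methoxy from the trimethoxy aryl ring

The compounds below may be only part of what the source reports. "The series", "measured", "known", "first", "only" and "open" are said of these compounds alone.

Compound 2 `COc1cc(-c2cc(/C=C/C(=O)c3ccc(N)cc3)[nH]n2)cc(OC)c1OC` and compound 1 `COc1ccc(-c2cc(/C=C/C(=O)c3ccc(N)cc3)[nH]n2)cc1` share the same core. In a functional assay on MDA-MB-231 cells (Homo sapiens) for inhibition, read by sulforhodamine B assay, with a stated time of 48 h (a higher number here means a weaker inhibitor of growth, a lower number a stronger inhibitor of growth), compound 1 gives 8290 nM, and in this assay compound 2 gives 12200 nM; the two numbers lie within the scatter of each other. Compound 3 `COc1ccc(-c2cc(/C=C/C(=O)c3ccc(N)cc3)[nH]n2)cc1OC` differs from compound 2 by hydrogen in place of methoxy on an aromatic carbon. Among the compounds with values here, with no comparable pair available, only a small shift is expected, with the estimated step of a 1.2-fold lower number from compound 2 to compound 3 (0.09 log units; within the scatter) staying within the scatter. In this assay compound 3 is estimated at 10000 nM, with a likely range from 4000 nM to 25000 nM.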

Compound 3, concentration for total growth inhibition: 17200 nM
The estimate for compound 3 lay 1.7-fold (0.24 log units) below the measured number; the range from low to high includes it.
By their numbers in this assay, from the lowest: compounds 1, 2 and 3 (each within the scatter of the next, the first and the last beyond it).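

In this assay, taking this methoxy away gives a 1.4-fold higher number from compound 2 to compound 3 (0.15 log units; within the scatter) and so does not resolve any effect of the change at this position. The other single change leading to compound 3, methoxy in place of hydrogen on an aromatic carbon, gives a 2.1-fold higher number from compound 1 to compound 3 (0.32 log units; beyond the scatter) and is a modest step, the only one here beyond the scatter. Nothing available bears on the reason for either step.

The compounds shown leave open how a hydroxyl, a fluorine or an ethoxy group on this aromatic carbon would read in this assay.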